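This account rests on a few compounds, and the source may have more. Where it says the series, first, only, none or still open, it means among the compounds named here.

Measured so far in a functional assay on the whole organism with Rattus norvegicus as the target; on this read-out lower numbers stand for an effect already at smaller amounts and higher numbers for an effect only at larger amounts of compound:

- Compound 1 `Cc1cc(C)c(NC(=O)N(Cc2ccc(Oc3ccc(F)cc3)cc2)C2CCCCCC2)c(C)n1`: 0.044 mg/kg
- Compound 2 `COc1nc(C)ccc1NC(=O)N(Cc1ccc(Oc2ccc(F)cc2)cc1)C1CCCCCC1`: > 0.1 mg/kg (a limit)
- Compound 3 `CSc1cc(C)nc(SC)c1NC(=O)N(Cc1ccc(Oc2ccc(F)cc2)cc1)C1CCCCC1`: < 0.01 mg/kg (a limit)

Compound 3 has no exact number. It stands at the limit of < 0.01 mg/kg in this assay, at which 1 of the 3 values shown sits, and that is a limit. Compound 2 stands at the limit of > 0.1 mg/kg in this assay, at which 1 of the 3 values shown sits, which is also a limit. Compound 1 is the only one of the three with an exact number, 0.044 mg/kg.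

The next compound is compound 4 `CSc1cc(C)nc(SC)c1NC(=O)N(CCCc1ccccc1)Cc1ccc(Oc2ccc(F)cc2)cc1`, which differs from compound 3 in one group: 3-phenylpropyl in place of cyclohexyl on an amide-type nitrogen. Put simply, 3-phenylpropyl takes the place of cyclohexyl on an amide-type nitrogen, so a non-aromatic ring of carbon gives way to a group carrying an aromatic ring.

For the measured compounds named here, only one measured step is available, an at least 2.2-fold higher number from compound 1 to compound 2 (0.35 log units; beyond the scatter). It concerns a different group, so it does not test this exchange directly. It does show that a single exchange can move the number in this assay beyond the scatter, and that the move can be modest in size.

A modest move toward a higher number is therefore expected in this assay, though the direction is uncertain. The expected change is an at least 2.0-fold higher number from compound 3 to compound 4 (0.30 log units; that floor lies within the scatter). For compound 4 the estimated value is 0.02 mg/kg, with an expected range from 0.004 mg/kg to 0.1 mg/kg.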

Compound 4, dose for half-maximal effect: 0.025 mg/kg
Beside the measured number, compound 4's estimate is 1.3-fold (0.10 log units) below it; the measured number falls inside the stated range.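

For the compounds shown here, putting 3-phenylpropyl in place of cyclohexyl on an amide-type nitrogen gives, in this assay, an at least 2.5-fold higher number from compound 3 to compound 4 (0.39 log units; beyond the scatter), so this is the first measured change at this position; the earlier step concerned a different group. On these data alone, compound 3 carries only a limit, so the step sets a floor and its full size stays unknown: the limit of < 0.01 mg/kg in this assay, at which 1 of the 4 values shown sits. Compound 4 nevertheless gives an exact number, 0.025 mg/kg, which shows that this nitrogen can carry a chain ending in an aromatic ring as well as a non-aromatic ring of carbon, and still give a measurable effect in the whole animal.

This single exchange alters the ring and adds a chain at the same time, so the compounds shown cannot say which of the two goes with the higher number; a 3-cyclohexylpropyl group, which keeps the chain but has the non-aromatic ring, would separate them. As far as these compounds go, how an amine or a carboxylic acid at the end of the chain would read in this assay also remains open.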